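A few compounds are considered here, and "the series" means these few. Any claim that something is new, unique, unknown or untested is made for them only; others in the source may bear on it.

Measured so far in a functional assay on HeLa S3 cells (Homo sapiens) for antiproliferative activity, read by XTT assay, with a stated time of 72 h (on this read-out lower numbers stand for stronger inhibition and higher numbers for weaker inhibition), and nothing else in the series:

- compound 1 `COc1ncnc2c1c(-c1cc3ccccc3o1)cn2[C@@H]1O[C@H](CO)[C@@H](O)[C@H]1O` gives 9240 nM
- compound 2 `CNc1ncnc2c1c(-c1ccco1)cn2[C@@H]1O[C@H](CO)[C@@H](O)[C@H]1O` gives 5000 nM
- compound 3 `Cc1nc(N)c2c(-c3ccoc3)cn([C@@H]3O[C@H](CO)[C@@H](O)[C@H]3O)c2n1` gives > 20000 nM

Compound 3 stands at the limit of > 20000 nM in this assay, at which 1 of the 3 values shown sits, and its entry is a limit, not a number. Any step away from compound 3 therefore has an open starting point.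

The next compound is compound 4 `Cc1nc(N)c2c(-c3cc4ccccc4o3)cn([C@@H]3O[C@H](CO)[C@@H](O)[C@H]3O)c2n1` which has 1-benzofuran-2-yl in place of furan-3-yl on an aromatic carbon with the rest of the structure unchanged. Among the measured compounds shown here, no measured pair isolates this change, so the expectation is weak.

For the measured compounds named here, the only support is compound 1 with 9240 nM as a measured number, which carries the same 1-benzofuran-2-yl group on a different core. On that basis a modest move toward stronger inhibition is expected in this assay although compound 4 may well end at the same limit. The expected size of the change is an at least 1.4-fold lower number from compound 3 to compound 4 (0.15 log units; that floor lies within the scatter) and this is an estimate from thin evidence. For compound 4 the estimated value is 14000 nM with an expected range of 5000 nM to 30000 nM on this read-out.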

Compound 4, half-maximal inhibitory concentration: > 20000 nM
Compound 4 was reported as a limit (the forecaster's own chance of this, stated with the estimate: 45%); middle value at least 1.4-fold (0.15 log units) from the limit.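

In this assay compound 3 and compound 4 are both entries at a limit, so no step can be read between them and the exchange of furan-3-yl for 1-benzofuran-2-yl has no readable size: the limit of > 20000 nM in this assay, at which 2 of the 4 values shown sit. The compounds shown leave open how these two groups compare on a shared core where both give numbers.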